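Furan-2-yl in place of phenyl, among readings at a limit

The source may hold more compounds than are shown below. What is called first, only, known or untested is meant among the compounds shown, and "the series" means these compounds.

Of the compounds shown here, three sharing one core have been read so far in a functional assay on MDA-MB-231 cells (Homo sapiens) for inhibition, read by CCK-8 assay, with a stated time of 48 h; on this read-out higher numbers stand for weaker inhibition of growth and lower numbers for stronger inhibition of growth. Compound 1 (`Cc1ccccc1Nc1nc(NC2CC2)ncc1Cl`), with cyclopropyl on the nitrogen, gives only a limit (> 100000 nM). Compound 2 (`Cc1ccccc1Nc1nc(Nc2ccccc2)ncc1Cl`), with phenyl there, also gives only a limit (> 100000 nM). Compound 3 (`Cc1ccccc1Nc1nc(NCc2ccccc2)ncc1Cl`), with benzyl there, likewise stands at a limit (> 100000 nM) and has no number of its own. All readings so far therefore sit together (the limit of > 100000 nM in this assay, at which 3 of the 3 values shown sit).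

Compound 4 (`Cc1ccccc1Nc1nc(NCc2ccco2)ncc1Cl`) follows from compound 3 by one change: furan-2-yl in place of phenyl on a saturated chain carbon bound to a nitrogen on an aromatic ring. The measured steps that bear on it are (a step that the two limits leave unreadable from compound 1 to compound 3) and (a step that the two limits leave unreadable from compound 2 to compound 3), and neither has a size that can be carried over. No step beyond the scatter is therefore expected in this assay, and no direction can be argued. The expected step is (a number no higher from compound 3 to compound 4 (the limit leaves the size open)). Compound 4 is estimated at 100000 nM (expected range 30000 nM to 200000 nM), and it may well be reported again only as a limit.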

Compound 4, concentration for 50% growth inhibition: > 100000 nM
Compound 4: a limit, no number; the forecaster's own chance of this, stated with the estimate: 75%; the middle value sits exactly at the limit.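

In this assay compound 4 gives > 100000 nM, a limit and not a number, so its steps from compound 1, compound 2 and compound 3 cannot be read. The compounds shown leave open whether these groups differ in growth inhibition at all, with every reading at one limit: the limit of > 100000 nM in this assay, at which 4 of the 4 values shown sit.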